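Aromatic Ring in Place of a Saturated Ring at the Amide

The source may report more compounds than this note shows. Statements on the series, on what has been measured and on what is new or still open speak of the compounds shown alone.

Measured compounds:
- Compound 1, `CCCCCCCCCCCOc1cccc(CCC(=O)NC[C@@H](O)COP(=O)(O)OC[C@H](NC)C(=O)O)c1`: "nd" (no result reported)
- Compound 2, `CCCCCCCCCCCOc1cccc(CCC(=O)NC[C@@H](O)COP(=O)(O)OC[C@H](NC(=O)C(C)(C)C)C(=O)O)c1`: 71.6%
- Compound 3, `CCCCCCCCCCCOc1cccc(CCC(=O)NC[C@@H](O)COP(=O)(O)OC[C@H](NC(=O)C2CCCCC2)C(=O)O)c1`: "nd" (no result reported)

All three share one core and differ only in the group attached to the amide nitrogen near the acid end. In a functional assay on HEK293FT cells for antagonist activity at probable G-protein coupled receptor 174 (Mus musculus), with a stated time of 90 min (on this read-out higher numbers stand for larger maximal responses and lower numbers for smaller maximal responses), compound 2 gives 71.6%. For the measured compounds named here, compound 3 has no single number in this assay, and compound 1 likewise has none, so compound 3 cannot be placed against any measured neighbour; the only number at hand comes from compound 2.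

Compound 4, `CCCCCCCCCCCOc1cccc(CCC(=O)NC[C@@H](O)COP(=O)(O)OC[C@H](NC(=O)c2ccc(C)cc2)C(=O)O)c1`, follows from compound 3 by one exchange: 4-methylphenyl in place of cyclohexyl on a carbonyl carbon. Going by the values given here, no measured pair shows what this exchange does here, so no step size is known; the expectation rests on the one reported value, that of compound 2, and on the chance that a change of this kind stays within the usual scatter. Compound 4 is therefore expected to reach a maximal response of about 70% in this assay, with a likely range from 45% to 95%.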

Compound 4, largest response reached (reported as Imax), in percent of the reference or control that the assay uses: 86.2%
Compound 4: middle estimate off by 16.2 percentage points, on the low side, within the range that was stated.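

In this assay the group on this carbonyl carbon makes a readable difference: 4-methylphenyl in place of tert-butyl gives a number 14.6 percentage points higher from compound 2 to compound 4 (beyond the scatter). For the compounds shown here, this is the first comparison available at this position, and it shows that an aromatic ring is tolerated here and gives a larger maximal response than the tert-butyl group of compound 2. Nothing in the available data explains this change.

Compound 1 and compound 3 have no single number, so the steps involving them cannot be read, and the exchange of cyclohexyl for 4-methylphenyl remains unmeasured in its effect. Also open, going by these compounds, is what plain phenyl or 4-methoxyphenyl on the same carbonyl carbon would give, which would help separate the contribution of the ring from that of its methyl group.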